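Trading a Bicyclic Amide Partner for a Methylcarbamoylphenyl Group

This account rests on a few compounds, and the source may have more. Where it says the series, first, only, none or still open, it means among the compounds named here.

Measured compounds:
- compound 1, `COc1ccc(NC(=O)[C@H]2CCCN2C(=O)C2(c3ccc(Cl)cc3)CCCC2)cc1`, 7.94 nM
- compound 2, `O=C(Nc1ccc2[nH]c(=O)[nH]c2c1)[C@H]1CCCN1C(=O)C1(c2cccc(Cl)c2)CCCC1`, 0.398 nM
- compound 3, `COc1ccc(NC(=O)[C@H]2CCCN2C(=O)C2(c3ccc(Cl)cc3)CCC2)cc1`, 10 nM

All three were tested in an assay on isolated protein for inhibition of histone acetyltransferase p300 (Homo sapiens), with a stated time of 60 min; a lower number here means a stronger inhibitor, a higher number a weaker inhibitor. Compound 2 has the lowest number of the three, and its gaps to compound 1 and to compound 3 are both well beyond the usual scatter of repeated measurements, so on these data compound 2 is the most potent of the set. Compound 1 and compound 3 carry a methoxyphenyl group on the amide nitrogen, whereas compound 2 carries a larger two-ring group there, which may be part of why compound 2 separates itself.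

Compound 4, `CNC(=O)c1cccc(NC(=O)[C@H]2CCCN2C(=O)C2(c3cccc(Cl)c3)CCCC2)c1`, has not yet been measured in this assay. Compared with compound 2, the change is a group of 10 heavy atoms (8 carbon, 1 nitrogen, 1 oxygen; one six-membered aromatic ring of carbon only) in place of a group of 10 heavy atoms (7 carbon, 2 nitrogen, 1 oxygen; one five-membered aromatic ring with 2 hetero atoms, one six-membered aromatic ring of carbon only), on an amide-type nitrogen. The entering group is a single aromatic ring, closer in size and shape to the methoxyphenyl groups of compound 1 and compound 3, which gave higher numbers than compound 2. A step back toward those higher numbers is therefore expected, though not necessarily all the way, since the entering group keeps a hydrogen-bond donor.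

Compound 4 is estimated at 2 nM, with a plausible range from 0.5 nM to 8 nM. This estimate means an expected step of a 5.0-fold higher number from compound 2 to compound 4 (0.70 log units; beyond the scatter), a loss of potency beyond the scatter.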

Compound 4, half-maximal inhibitory concentration: 1260 nM
Compound 4: the middle estimate sits 630-fold (2.80 log units) below what was measured; the whole stated range lies below it.
By their numbers in this assay, from the lowest: compound 2; then compounds 1 and 3 (each within the scatter of the next); then compound 4.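

In this assay the swap of the two-ring group on the amide-type nitrogen for 3-(methylcarbamoyl)phenyl gives a 3200-fold higher number from compound 2 to compound 4 (3.50 log units; beyond the scatter) even though both groups hold 10 heavy atoms, so a matching atom count is far from enough to keep potency at this position. The group that leaves has a five-membered aromatic ring with 2 hetero atoms fused into its two-ring system and 2 hydrogen-bond donors, while the group that enters has one six-membered aromatic ring of carbon only and 1 hydrogen-bond donor, and the hydrogen-bond donor and acceptor that remain do not hold on to the low number of compound 2. Nothing available shows which of these differences accounts for the loss.

On these data alone, with a single replacement at this position, the ring, the donor count and the placement of the methylcarbamoyl group all change or stay untested together, so their separate shares remain open. Also open, as far as these compounds go, is whether a phenyl ring carrying an amine or a carboxylic acid in place of the methylcarbamoyl group would recover any of the lost potency.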